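This account rests on a few compounds, and the source may have more. Where it says the series, first, only, none or still open, it means among the compounds named here.

Working notes on the series. Among the compounds with values here, compound 1 `Cc1cc(C)c(CN2CCc3c(Cl)cc([C@H](CO)[C@H]4CCOC4)c(Cl)c3C2=O)c(=O)[nH]1` is the one member with a single number: in an assay for inhibition of histone-lysine N-methyltransferase EZH2 variant Y641N (Homo sapiens), read by scintillation counting, with a stated time of 60 min, in the presence of a further agent that is not named here (a higher number here means a weaker inhibitor, a lower number a stronger inhibitor), compound 1 gives 0.24 nM. Compound 2 `COC(c1cc(Cl)c2c(c1Cl)C(=O)N(Cc1c(C)cc(C)[nH]c1=O)CC2)C1CCN(C2COC2)CC1` has several entries, (the several entries of compound 2 in this assay, 530 nM; 0.64 nM (2 entries)), and compound 3 `COC(c1cc(Cl)c2c(c1Cl)C(=O)N(Cc1c(C)cc(C)[nH]c1=O)CC2)C1CCN(C(=O)CO)CC1` likewise, (the several entries of compound 3 in this assay, 70 nM; 0.25 nM (2 entries)); in this assay compound 2 gives 530 nM; 0.64 nM (2 entries) and compound 3 gives 70 nM; 0.25 nM (2 entries), so neither supplies a firm reference point. Compound 4 `Cc1cc(C)c(CN2CCc3c(Cl)cc([C@@H](C)CO)c(Cl)c3C2=O)c(=O)[nH]1` is not yet measured. It differs from compound 1 by methyl in place of oxolan-3-yl on a saturated chain carbon bound to an aromatic carbon and a saturated chain carbon. Within the data shown here, no measured pair isolates this change, so the expectation rests on compound 1 alone. A modest loss is expected, a 4.2-fold higher number from compound 1 to compound 4 (0.62 log units; beyond the scatter), somewhat beyond the scatter. Compound 4 is therefore estimated at 1 nM in this assay, within the range 0.2 nM to 6 nM.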

Compound 4, inhibition constant: 260 nM
Compound 4: middle estimate off by 260-fold (2.41 log units), on the low side; the measured number lies above the stated range.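

Within the data shown here, at the saturated chain carbon bound to an aromatic carbon and a saturated chain carbon, the substituent matters greatly: methyl in place of oxolan-3-yl gives a 1100-fold higher number from compound 1 to compound 4 (3.03 log units; beyond the scatter), the first step that isolates one change. The size of this step rests on single numbers, and one compound can carry entries far apart in this assay: the several entries of compound 2 in this assay, 530 nM; 0.64 nM (2 entries). The same holds for a second compound: the several entries of compound 3 in this assay, 70 nM; 0.25 nM (2 entries)

Whether the ring or its oxygen accounts for the step remains open. Cyclopentyl or a longer chain such as propyl at this carbon would separate the two.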